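A few compounds are considered here, and "the series" means these few. Any claim that something is new, unique, unknown or untested is made for them only; others in the source may bear on it.

Compound 1 `CCOC(=O)c1sc(Nc2nc(N3CCC(O)CC3)cc(N3CCC(N(C)C)CC3)n2)nc1C`: 20 ug/mL in a physicochemical assay for solubility, at pH 6.5; on this read-out lower numbers stand for lower solubility and higher numbers for higher solubility
Compound 2 `CCOC(=O)c1sc(Nc2nc(N3CCC(N(C)C)CC3)cc(N3CCCC(CO)C3)n2)nc1C`: 20 ug/mL in this assay

For the measured compounds named here, compound 1 stands level with compound 2, the only other compound measured so far. Compound 3 `CCOC(=O)c1sc(Nc2nc(N3CCC(O)CC3)cc(N3CCC(O)CC3)n2)nc1C` differs from compound 1 in one place: hydroxy in place of dimethylamino on a saturated ring carbon. Hydroxy takes the place of dimethylamino on a saturated ring carbon, so 4-(dimethylamino)piperidin-1-yl becomes 4-hydroxypiperidin-1-yl. Going by the values given here, the one measured step, no change at the digits printed from compound 1 to compound 2 (within the scatter), concerns a different group, and both measured compounds keep the dimethylamino group. Among the compounds with values here, no measurement yet tests this change, so the expectation is a loose one. A fall in this assay is expected, though its size is uncertain, and the expected step is a 3.3-fold lower number from compound 1 to compound 3 (0.52 log units; beyond the scatter). Compound 3 is estimated at 6 ug/mL, with an expected range of 1.5 ug/mL to 20 ug/mL.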

Compound 3, solubility: 20 ug/mL
Compound 3: middle estimate off by 3.3-fold (0.52 log units), on the low side, and the stated range covers the measured number.
By their numbers in this assay, from the lowest: compounds 1, 2 and 3 (each within the scatter of the next).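

In this assay the swap of 4-(dimethylamino)piperidin-1-yl for 4-hydroxypiperidin-1-yl gives no change at the digits printed from compound 1 to compound 3 (within the scatter) and so leaves the number level at this saturated ring carbon. Both earlier compounds carried the dimethylamino group, so neither could show what happens without it; compound 3 shows that, with hydroxy in its place, the dimethylamino group is not needed to hold this number. No supporting data bear on why the number stays level.

As far as these compounds go, whether a carboxylic acid, a longer chain ending in an amine, or a bare ring carbon with no group at all would also leave the number level remains open. So does whether the same swap would read the same way with a different group on the other piperidine ring.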